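This account rests on a few compounds, and the source may have more. Where it says the series, first, only, none or still open, it means among the compounds named here.

Values so far in a functional assay on MCF7 cells (Homo sapiens) for cytotoxicity, read by MTT assay, with a stated time of 48 h (a higher number here means a weaker inhibitor, a lower number a stronger inhibitor), are these:

- compound 1 `C/C(=N\NC(=S)Nc1ccccc1I)c1ccccn1` gives 4.1 nM
- compound 2 `C/C(=N\NC(=S)Nc1ccc(I)cc1)c1ccccn1` gives 6.61 nM
- compound 3 `CC(=NNC(=S)Nc1cccc([N+](=O)[O-])c1)c1ccccn1` gives 38 nM

Compound 3 has the highest number of the three, beyond the scatter from both others, so it is the weakest inhibitor of this set. Compound 4 `CC(=NNC(=S)Nc1cccc(I)c1)c1ccccn1` has not been measured. It differs from compound 3 by iodo in place of nitro on an aromatic carbon with iodo in place of nitro on an aromatic carbon, meta to a large group. Compound 1 at 4.1 nM and compound 2 at 6.61 nM both carry iodo, and both numbers lie well under that of compound 3. Only these two compounds support the comparison, yet a fall beyond the scatter in this assay seems likely. The expected size of the step of a 5.4-fold lower number from compound 3 to compound 4 (0.73 log units; beyond the scatter) is an estimate only. For compound 4 the estimated value is 7 nM within an expected range of 2.5 nM to 20 nM in this assay.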

Compound 4, half-maximal inhibitory concentration: 45 nM
The estimate for compound 4 lay 6.4-fold (0.81 log units) below the measured number, and the stated range ends below it.
By their numbers in this assay, from the lowest: compounds 1 and 2 (each within the scatter of the next); then compounds 3 and 4 (each within the scatter of the next).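

In this assay, nitro and iodo on this aromatic carbon, meta to a large group, cannot be told apart, with a 1.2-fold higher number from compound 3 to compound 4 (0.07 log units; within the scatter) as the step. Carrying iodo therefore does not by itself give numbers like those of compound 1 (4.1 nM) and compound 2 (6.61 nM), though those two differ from compound 4 in where the iodo sits. Nothing available explains this result. For the compounds shown here, how an amine or a carboxylic acid at this place would read stays open, since these compounds show only two groups there.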